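Para-selenocyanato carbamates: removing a methoxy group

This account rests on a few compounds, and the source may have more. Where it says the series, first, only, none or still open, it means among the compounds named here.

Measured so far:
compound 1 `COc1ccc(OC(=O)Nc2ccc([Se]C#N)cc2)cc1` — 70000 nM
compound 2 `CC(C)COC(=O)Nc1ccc([Se][Se]c2ccc(NC(=O)OCC(C)C)cc2)cc1` — 70200 nM
compound 3 `Cc1ccc(OC(=O)Nc2ccc([Se][Se]c3ccc(NC(=O)Oc4ccc(C)cc4)cc3)cc2)cc1` — 75600 nM

Of the compounds shown here, three have been tested in a functional assay on CCRF-CEM cells (Homo sapiens) for cytotoxicity, read by MTT assay, with a stated time of 72 h; a higher number here means that more compound is tolerated, a lower number that less compound is tolerated. Compound 1 gives 70000 nM. Compound 2, a diselenide with two isobutyl carbamates, gives 70200 nM. Compound 3, a diselenide carrying two aryl carbamates, gives 75600 nM. Within the data shown here, the three numbers sit together: the gaps from compound 1 to compound 2 and to compound 3 both lie within the usual scatter of repeated measurements, so none of the three can be set apart from the others on these numbers, and no step between them is counted as a real difference.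

The next compound, compound 4 `N#C[Se]c1ccc(NC(=O)Oc2ccccc2)cc1`, keeps the selenocyanate and the aryl carbamate of compound 1 and differs in one place: hydrogen in place of methoxy on an aromatic carbon. Among the measured compounds shown here, no pair of measured compounds shows what such a change does in this assay, so there is nothing to point either way.

With the three measured values lying flat, the expected step of no change at the digits printed from compound 1 to compound 4 (within the scatter) is none beyond the scatter. For compound 4 the estimate is 70000 nM, with a range from 30000 nM to 160000 nM.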

Compound 4, concentration lethal to 50% of the cells: 73200 nM
Beside the measured number, compound 4's estimate is 1.0-fold (0.02 log units) below it, within the range that was stated.
By their numbers in this assay, from the lowest: compounds 1, 2, 4 and 3 (each within the scatter of the next).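

Compound 4 gives the series its first step that changes one place only. In this assay, hydrogen in place of methoxy on an aromatic carbon of the six-membered aromatic ring, para to a large group, gives a step that does not stand out from repeated measurement (a 1.0-fold higher number from compound 1 to compound 4 (0.02 log units; within the scatter)). At this position, then, the loss of methoxy, with its 2 heavy atoms and 1 hydrogen-bond acceptor, leaves the reading unresolved from that of compound 1, and nothing available bears on why this is so.

Only methoxy and hydrogen have been compared at this position, so this single step cannot show whether the place is insensitive to substitution in general or only to this exchange. An amine, a carboxylic acid or a longer alkoxy chain on the same aromatic carbon, with the selenocyanate and the carbamate kept as in compound 4, would test whether any group there can move the number beyond the scatter.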